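Removing the N-methyl of the core: a hydrogen check

The source may hold more compounds than are shown below. What is called first, only, known or untested is meant among the compounds shown, and "the series" means these compounds.

Measured so far:
Compound 1 `Cn1c(-c2cccnc2)nc2ccc(F)cc21` — 12 nM in an assay on V79 cells for inhibition of cytochrome P450 11B2, mitochondrial (Homo sapiens), read by HTRF, with a stated time of 1 h; on this read-out higher numbers stand for weaker inhibition and lower numbers for stronger inhibition
Compound 2 `Fc1cncc(-c2nc3cc(F)c(Cl)cc3n2C2CC2)c1` — 0.8 nM in this assay

Among the measured compounds shown here, compound 1 stands at the higher of the two numbers so far; compound 2, which differs from it at several places, gives a lower number, and the gap between them lies beyond the scatter. For the measured compounds named here, no pair measured so far differs in one place only, so no single step is known yet.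

Compound 3 `Fc1ccc2nc(-c3cccnc3)[nH]c2c1` has not been measured. It differs from compound 1 by hydrogen in place of methyl on an aromatic nitrogen. Taking compound 1 as the reference with 12 nM, the expectation for this assay is a weakening, a step of modest size that could still lie beyond the scatter, since the only lower number in the set belongs to compound 2 0.8 nM, which carries a larger group on that nitrogen. The estimated step from compound 1 to compound 3 is a 3.3-fold higher number from compound 1 to compound 3 (0.52 log units; beyond the scatter). Compound 3 is estimated at 40 nM, within 8 nM to 200 nM.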

Compound 3, half-maximal inhibitory concentration: > 10000 nM
Compound 3: no number, only a limit; the forecaster's own chance of this, stated with the estimate: 5%; middle value at least 250-fold (2.39 log units) away from the limit.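

Compound 3 gives > 10000 nM in this assay, which is a limit of the assay and not a number. Among the compounds shown here, the first single-place step, hydrogen in place of methyl on an aromatic nitrogen, gives an at least 830-fold higher number from compound 1 to compound 3 (2.92 log units; beyond the scatter), so within this pair the single methyl separates a measurable number from none, something the earlier comparison, with its several differences, could not show. The true size of this step stays unknown, since only a bound on it can be read: the limit of > 10000 nM in this assay, at which 1 of the 3 values shown sits.

Still open, on these data alone, is how the read-out responds at this nitrogen to ethyl, a longer chain or a chain ending in an amine. How much of the lower number of compound 2 belongs to its larger group on this nitrogen, rather than to its other differences, cannot be read from the compounds shown.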